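Removing One Ester From a Nucleoside Triester: Solubility Outlook

The compounds below may be only part of what the source reports. "The series", "measured", "known", "first", "only" and "open" are said of these compounds alone.

Measured compounds:
compound 1, `COc1ncnc2c1ncn2[C@@H]1O[C@H](COC(=O)C(C)C)[C@@H](OC(=O)C(C)C)[C@@H]1OC(=O)C(C)C`, 141000 nM
compound 2, `COc1ncnc2c1ncn2[C@@H]1O[C@H](COC(=O)c2ccc(Cl)cc2)[C@@H](OC(=O)c2ccc(Cl)cc2)[C@@H]1OC(=O)c1ccc(Cl)cc1`, which in this assay reaches only a limit, < 5000 nM
compound 3, `COc1ncnc2c1ncn2[C@@H]1O[C@H](CO)[C@@H](OC(=O)C(C)C)[C@@H]1OC(=O)C(C)C`, 3300000 nM

In a physicochemical assay for solubility, in phosphate buffer (on this read-out lower numbers stand for lower solubility and higher numbers for higher solubility), compound 1 holds the lower of the two numbers given. Within the data shown here, the only step measured here, a 23-fold higher number from compound 1 to compound 3 (1.37 log units; beyond the scatter), is large. Compound 2 is known only as a limit (the limit of < 5000 nM in this assay, at which 1 of the 3 values shown sits).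

Compound 4, `COc1ncnc2c1ncn2[C@@H]1O[C@H](COC(=O)C(C)C)[C@@H](O)[C@@H]1OC(=O)C(C)C`, differs from compound 1 by hydrogen in place of isopropylcarbonyl on an oxygen on a saturated carbon, the same kind of change as between compound 1 and compound 3, here on an oxygen on a saturated carbon whose other neighbour is a saturated ring carbon. On that basis a large rise is expected, an 18-fold higher number from compound 1 to compound 4 (1.25 log units; beyond the scatter). Compound 4 is estimated at 2500000 nM, with a range from 800000 nM to 6000000 nM.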

Compound 4, solubility: 9110000 nM
Compound 4: the middle estimate sits 3.6-fold (0.56 log units) below what was measured, outside the stated range (above it).
By their numbers in this assay, from the lowest: compound 1; then compound 3; then compound 4. At a limit, below all of these: compound 2.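

In this assay, hydrogen in place of isopropylcarbonyl on an oxygen on a saturated carbon whose other neighbour is a saturated ring carbon gives a 65-fold higher number from compound 1 to compound 4 (1.81 log units; beyond the scatter). Set beside a 23-fold higher number from compound 1 to compound 3 (1.37 log units; beyond the scatter), this shows that the change gives a large step at two different oxygens of compound 1, not at one alone. Nothing shown gives a cause for this step. From the compounds shown here alone, it remains open whether an amine or a longer chain at this place would give a step of similar size.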